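A few compounds are considered here, and "the series" means these few. Any claim that something is new, unique, unknown or untested is made for them only; others in the source may bear on it.

In an assay on microsomes from intestine for inhibition of acyl-CoA:cholesterol acyltransferase (Oryctolagus cuniculus) (on this read-out lower numbers stand for stronger inhibition and higher numbers for weaker inhibition), compound 3 `O=C(NCC1(c2ccccc2)CCCCC1)Nc1ccccc1` gives 2300 nM, the highest number among the three measured compounds. Compound 1 `CC(C)c1cccc(C(C)C)c1NC(=O)NC(c1ccccc1)c1ccccc1` gives 45 nM and compound 2 `CC(C)c1cccc(C(C)C)c1NC(=O)NCC1(c2ccsc2)CCCC1` gives 18 nM; both gaps to compound 3 lie well beyond the usual scatter, so compound 3 is clearly the weakest inhibitor of the three. Compound 4 `Cc1cccc(NC(=O)NCC2(c3ccccc3)CCCCC2)c1` differs from compound 3 by one change, (methyl in place of hydrogen on an aromatic carbon), on an aromatic carbon of a six-membered aromatic ring of carbon only, meta to a large group. Among the measured compounds shown here, no measured pair isolates this change, so the expectation rests on compound 3 alone. In this assay the step of a 1.9-fold lower number from compound 3 to compound 4 (0.28 log units; within the scatter) is expected to be small, toward stronger inhibition. Compound 4 is therefore estimated at 1200 nM, with a range from 400 nM to 4000 nM.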

Compound 4, half-maximal inhibitory concentration: 2800 nM
For compound 4 the middle estimate is 2.3-fold (0.37 log units) below the measured one; low and high end bracket the measured number.
By their numbers in this assay, from the lowest: compound 2; then compound 1; then compounds 3 and 4 (each within the scatter of the next).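

In this assay, among the compounds shown here, placing a methyl on this aromatic carbon, meta to a large group, gives a 1.2-fold higher number from compound 3 to compound 4 (0.09 log units; within the scatter) and so offers the first comparison of compounds that differ in one place. Going from phenyl to 3-methylphenyl therefore does not separate compound 4 from compound 3 on this read-out. Nothing available here explains this result.

Going by these compounds, whether a chlorine, a methoxy group or an amine on this same carbon would also leave the number unchanged stays open. Compound 1 and compound 2 differ from compound 3 in more than one place, so the part responsible for their lower numbers cannot be read.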